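From Trifluoromethoxy to Fluoro: Compound 3 to Compound 4

This account rests on a few compounds, and the source may have more. Where it says the series, first, only, none or still open, it means among the compounds named here.

Measured in a functional assay on HCT-15 cells (Homo sapiens) for cytotoxicity, read by MTT assay, with a stated time of 2 days; a higher number here means a weaker inhibitor, a lower number a stronger inhibitor:
Compound 1 `Cc1ccc2c(=O)[nH]c(-c3ccccc3C)nc2c1`: 11900 nM
Compound 2 `Cc1cccc(-c2nc3ccc(C)cc3c(=O)[nH]2)c1`: > 50000 nM
Compound 3 `Cc1ccc2c(=O)[nH]c(-c3ccccc3OC(F)(F)F)nc2c1`: 15900 nM

In this assay, for the measured compounds named here, compound 3 gives 15900 nM, within the scatter of compound 1, the only other number. Compound 2 shows > 50000 nM, which is a limit of the assay. Compound 4 `Cc1ccc2c(=O)[nH]c(-c3ccccc3F)nc2c1` follows from compound 3 by one change, fluoro in place of trifluoromethoxy on an aromatic carbon. Going by the values given here, one measured step bears on it, trifluoromethoxy in place of methyl: a 1.3-fold higher number from compound 1 to compound 3 (0.13 log units; within the scatter). That step stayed small, so no change beyond the scatter is expected, and the estimated step is a 1.1-fold lower number from compound 3 to compound 4 (0.03 log units; within the scatter). Compound 4 is estimated at 15000 nM, with an expected range from 6000 nM to 45000 nM.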

Compound 4, half-maximal inhibitory concentration: 10300 nM
The estimate for compound 4 lay 1.5-fold (0.16 log units) above the measured number; low and high end bracket the measured number.
By their numbers in this assay, from the lowest: compounds 4, 1 and 3 (each within the scatter of the next). At a limit, above all of these: compound 2.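

In this assay, fluoro on this aromatic carbon, ortho to a large group, brings no change beyond the scatter: a 1.5-fold lower number from compound 3 to compound 4 (0.19 log units; within the scatter), and a 1.2-fold lower number from compound 1 to compound 4 (0.06 log units; within the scatter). Methyl, trifluoromethoxy and fluoro at this place now give values all within the scatter of one another, so exchanging these three groups has not moved the number. Nothing measured here gives a reason for these small steps. As far as these compounds go, whether an amine or a carboxylic acid at this place would move the number beyond the scatter remains open.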